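A few compounds are considered here, and "the series" means these few. Any claim that something is new, unique, unknown or untested is made for them only; others in the source may bear on it.

Measured so far in a functional assay on KB cells (Homo sapiens) for cytotoxicity, read by MTT assay, with a stated time of 72 h; a higher number here means a weaker inhibitor, a lower number a stronger inhibitor:

compound 1 `Cc1ccc(C(=O)NC(=S)NNc2ncnc3ccccc23)cc1` — 10100 nM
compound 2 `COc1cc2ncnc(NNC(=S)NC(=O)c3cccc(Cl)c3)c2cc1OC` — 4830 nM
compound 3 `COc1cc2ncnc(NNC(=S)NC(=O)c3ccccc3OC)c2cc1OC` — 3850 nM

Compound 1 stands highest of the three numbers in this assay; compound 2 and compound 3 both lie lower, each by a gap beyond the scatter, while the values of compound 2 and compound 3 are within the scatter of each other. Both of those carry two methoxy groups on the shared core that compound 1 lacks, so the gap to compound 1 cannot be tied to the aryl group on the carbonyl carbon alone.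

Compound 4 `O=C(NC(=S)NNc1ncnc2ccccc12)c1ccccc1` differs from compound 1 in one place: hydrogen in place of methyl on an aromatic carbon. Going by the values given here, the only measured step, a 1.3-fold lower number from compound 2 to compound 3 (0.10 log units; within the scatter), also swaps the aryl on the carbonyl carbon, but it exchanges two substituted phenyls on the dimethoxy core, so it bears on the present change only loosely; it does show that a change at this position can pass without a shift beyond the scatter. Among the compounds with values here, no measured pair removes a methyl from this aryl ring. The working expectation is therefore a step of no more than the scatter, a 1.0-fold lower number from compound 1 to compound 4 (0.00 log units; within the scatter), with compound 4 close to compound 1. The estimate for compound 4 in this assay is 10000 nM, within a range of 4500 nM to 22000 nM.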

Compound 4, half-maximal inhibitory concentration: 2330 nM
Compound 4: middle estimate off by 4.3-fold (0.63 log units), on the high side; the whole stated range lies above it.
By their numbers in this assay, from the lowest: compounds 4, 3 and 2 (each within the scatter of the next, the first and the last beyond it); then compound 1.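

In this assay, the change from 4-methylphenyl to phenyl gives a 4.3-fold lower number from compound 1 to compound 4 (0.64 log units; beyond the scatter), so removing a single methyl para to a large group is enough to shift the number. The earlier step at the aryl group on the carbonyl carbon, a 1.3-fold lower number from compound 2 to compound 3 (0.10 log units; within the scatter), exchanged two substituted phenyls on a core with two methoxy groups and showed no shift beyond the scatter; the new pair, on a core without those methoxy groups, shows that this part of the molecule is not indifferent to change in this assay. No measurement at hand accounts for the direction or size of this step.

Going by these compounds, it remains open whether the same exchange of 4-methylphenyl for phenyl would give a comparable step on the core carrying two methoxy groups, since one pair cannot show whether the step carries over from one core to the other. Also open, on these data alone, is how an ethyl group, a fluorine or an amine at the same place on the ring would compare with hydrogen and methyl.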